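A few compounds are considered here, and "the series" means these few. Any claim that something is new, unique, unknown or untested is made for them only; others in the source may bear on it.

Four compounds are compared in a functional assay on MDA-MB-231 cells (Homo sapiens) for cytotoxicity, read by MTT assay; a higher number here means a weaker inhibitor, a lower number a stronger inhibitor. Compound 1 `COc1ccc(-n2cc(-c3ccc(OC)c(O)c3)nn2)cc1` and compound 2 `COc1ccc(-n2cc(-c3ccc(OC)c(OC)c3)nn2)cc1` share one core, while compound 3 `COc1ccc(-c2cn(-c3cc(OC)c(OC)c(OC)c3)nn2)cc1OC` and compound 4 `COc1cc(-c2cn(-c3cc(OC)c(OC)c(OC)c3)nn2)ccc1O` share another; the difference between the two cores is not broken down here.

In this assay compound 2 gives only a limit of the assay, > 100 nM. Compound 1 likewise gives only a limit, > 10000 nM. For compound 3 this assay gives "not determined" (no result reported).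

The change from compound 2 to compound 1 is hydrogen in place of methyl on an oxygen on an aromatic ring. From the compounds shown here alone, the step that the two limits leave unreadable from compound 2 to compound 1 cannot be read because the limit of > 100 nM in this assay, at which 1 of the 3 values shown sits, and the limit of > 10000 nM in this assay, at which 1 of the 3 values shown sits, are both limits and leave no number at either end, so its size is unknown.

Compound 4 carries the same change made on compound 3: hydrogen in place of methyl on an oxygen on an aromatic ring, at a place described in the same words. For the measured compounds named here, since compound 3 has no number in this assay, no step from compound 3 to compound 4 can be computed, and the expectation for compound 4 rests only on what the other pair shows.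

Going by the values given here, what can be said is that compound 1, the member of the first pair that carries the hydroxy, gave only the higher limit, > 10000 nM. On that slender basis compound 4 is expected to be a weak inhibitor in this assay, with an estimated value near 20000 nM and a likely range from 3000 nM to 100000 nM, with a real chance that only a limit is reported.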

Compound 4, half-maximal inhibitory concentration: > 10000 nM
Compound 4 was reported as a limit (the forecaster's own chance of this, stated with the estimate: 60%); the middle value is on the limit's open side.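

In this assay no new step can be read from compound 3 to compound 4, as compound 3 has no reported result to start from. Compound 4 gives only a limit: the limit of > 10000 nM in this assay, at which 2 of the 4 values shown sit. The compounds shown leave open how large the change from methoxy to hydroxy is in either pair, and whether it has the same size on both cores.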